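Halogen pattern on the aniline ring: outlook for compound 4

The source may hold more compounds than are shown below. What is called first, only, known or untested is meant among the compounds shown, and "the series" means these compounds.

Compound 1 `CN1CCN(CCCOc2cccc3nc(Nc4ccc(Cl)c(C(F)(F)F)c4)ccc23)CC1` gives 1690 nM in a functional assay on cells (Panel prostate (Carcinoma cell lines), Homo sapiens) for inhibition, read by sulforhodamine B assay, with a stated time of 48 h; a higher number here means a weaker inhibitor of growth, a lower number a stronger inhibitor of growth.
Compound 2 `CN1CCN(CCCOc2cccc3nc(Nc4ccc(Cl)c(F)c4)ccc23)CC1` gives 1760 nM in this assay.
Compound 3 `CN1CCN(CCCOc2cccc3nc(Nc4ccc(F)c(F)c4)ccc23)CC1` gives 4070 nM in this assay.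

Compound 3 carries the highest number of the three; compound 1 and compound 2 both sit below it beyond the scatter. Compound 4 `CN1CCN(CCCOc2cccc3nc(Nc4cc(Cl)cc(Cl)c4)ccc23)CC1` differs from compound 3 by 3,5-dichlorophenyl in place of 3,4-difluorophenyl on a nitrogen on an aromatic ring. The step bearing most directly on this is a 2.3-fold higher number from compound 2 to compound 3 (0.36 log units; beyond the scatter), fluoro replacing chloro; a 2.4-fold higher number from compound 1 to compound 3 (0.38 log units; beyond the scatter) points the same way. Among the measured compounds shown here, in compound 4 two fluorines give way to two chlorines, though the arrangement on the ring also changes, and no measured pair covers that part. A modest move toward a lower number in this assay is therefore expected, roughly reversing the step from compound 2. The estimate for compound 4 is 2000 nM (range 900 nM to 4500 nM), an expected step of a 2.0-fold lower number from compound 3 to compound 4 (0.31 log units; beyond the scatter).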

Compound 4, concentration for 50% growth inhibition: 1730 nM
The estimate for compound 4 lay 1.2-fold (0.06 log units) above the measured number; the range from low to high includes it.
By their numbers in this assay, from the lowest: compounds 1, 4 and 2 (each within the scatter of the next); then compound 3.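

Exchanging 3,4-difluorophenyl for 3,5-dichlorophenyl on the aniline nitrogen gives a clear gain in this assay (a 2.4-fold lower number from compound 3 to compound 4 (0.37 log units; beyond the scatter)). The other two comparisons stay within the scatter (a 1.0-fold lower number from compound 2 to compound 4 (0.01 log units; within the scatter); a 1.0-fold higher number from compound 1 to compound 4 (0.01 log units; within the scatter)), so this position accepts chlorines in a different arrangement, and among the four compounds only compound 3 stands apart. No measurement on hand accounts for this.

On these data alone, whether an unsubstituted phenyl or a single chlorine would hold this level remains open. So does the effect of a methoxy or nitrile on this ring.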